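Side-chain variation in a small amide series

The source may hold more compounds than are shown below. What is called first, only, known or untested is meant among the compounds shown, and "the series" means these compounds.

Measured so far:
compound 1 `COc1cc(N)c(Cl)cc1C(=O)NCC1CCNCC1` — 398 nM
compound 2 `COc1cc(N)c(Cl)cc1C(=O)NC1CCNCC1` — 398 nM

Both compounds were run in a functional assay on HEK293 cells for agonist activity at 5-hydroxytryptamine receptor 4 (Homo sapiens), read by cAMP accumulation; a lower number here means that less compound is needed, a higher number that more compound is needed for the effect. Compound 1 gives 398 nM, and compound 2 gives 398 nM. The two values are level at the digits given, so the difference between them lies within the scatter and no order can be read from it. Among the measured compounds shown here, compound 1 therefore stands at the same level as its nearest neighbour, compound 2, and the pair gives no measured step on which to rest a trend.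

Compound 3 `COc1cc(N)c(Cl)cc1C(=O)NCCN1CCNCC1` is not yet measured. It differs from compound 1 by (piperazin-1-yl)methyl in place of piperidin-4-yl on a saturated chain carbon bound to an amide-type nitrogen. For the measured compounds named here, with no characterised step between measured compounds, the expected size of this step rests on the structural change alone. The expectation for this assay is a move toward more compound being needed, of a size that may exceed the scatter but cannot be called certain. For compound 3 in this assay an estimate of 1000 nM is made, with a range from 300 nM to 4000 nM, which corresponds to an expected step of a 2.5-fold higher number from compound 1 to compound 3 (0.40 log units; beyond the scatter).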

Compound 3, half-maximal effective concentration: 501 nM
For compound 3 the middle estimate is 2.0-fold (0.30 log units) above the measured one, and the stated range covers the measured number.
By their numbers in this assay, from the lowest: compounds 1, 2 and 3 (each within the scatter of the next).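

Among the compounds shown here, the first measured step at this position comes from (piperazin-1-yl)methyl in place of piperidin-4-yl on a saturated chain carbon bound to an amide-type nitrogen, and in this assay it is a 1.3-fold higher number from compound 1 to compound 3 (0.10 log units; within the scatter). For the compounds shown here, compound 1 and compound 2 stood level and gave no step, whereas this pair shows that a change of ring, from one with 1 hetero atom to one with 2 hetero atoms, together with an added hydrogen-bond acceptor in the count for the entering group, stays within the scatter on the shared core. At this place, then, the read-out holds across a change in the ring itself, and not only across the two piperidine-bearing side chains already seen.

On these data alone, whether any side chain at this place gives a step beyond the scatter remains open, for example a longer chain ending in piperidin-4-yl, a morpholine ring or an open-chain dimethylamino group. Also open, as far as these compounds go, is what a methyl group on the free piperazine nitrogen would do in this assay. No measured evidence is at hand that accounts for the size of this step.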